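Swapping the Amine on an Ester Side Chain

A few compounds are considered here, and "the series" means these few. Any claim that something is new, unique, unknown or untested is made for them only; others in the source may bear on it.

Compound 2 `CC(=O)OC1CC2(N3CCCCC3)CC(c3ccccc3)C1C(c1ccccc1)C2` gives "not determined" (no result reported) in an ADME assay on L6 cells (Rattus norvegicus) for cytotoxicity, with a stated time of 72 h (a lower number here means a stronger inhibitor, a higher number a weaker inhibitor), so it offers no number to stand on. Compound 3 `CC(=O)OC1CC2(N(C)C)CC(c3ccccc3)C1C(c1ccccc1)C2` likewise gives "not determined" (no result reported) in this assay. For the measured compounds named here, the one number available comes from compound 1 `O=C(CN1CCCC1)OC1CC2(N3CCCCC3)CC(c3ccccc3)C1C(c1ccccc1)C2`, which in this assay gives 16400 nM, a weak effect. Compound 4 `CCN(CC)CC(=O)OC1CC2(N3CCCCC3)CC(c3ccccc3)C1C(c1ccccc1)C2` differs from compound 2 by diethylamino in place of hydrogen on a saturated chain carbon bound to a carbonyl carbon. Going by the values given here, with no value for compound 2, no step can be measured here; since compound 1 is a close relative of compound 4, a step in this assay of no more than the usual scatter is expected, in either direction. Compound 4 is estimated at 16000 nM in this assay, within a range from 6000 nM to 45000 nM, because compound 1 gives 16400 nM.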

Compound 4, half-maximal inhibitory concentration: 23900 nM
Compound 4: middle estimate off by 1.5-fold (0.17 log units), on the low side, within the range that was stated.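

In this assay the swap of pyrrolidin-1-yl for diethylamino on this saturated chain carbon bound to a carbonyl carbon gives a 1.5-fold higher number from compound 1 to compound 4 (0.16 log units; within the scatter) and so the two amines cannot be told apart at this position. Compound 2 has no single number, so the steps that would show what adding an amine to this chain does cannot be read. No evidence bears on this result. From the compounds shown here alone, whether a morpholin-4-yl group, a primary amine or a longer chain before the amine would read the same remains open.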